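A few compounds are considered here, and "the series" means these few. Any claim that something is new, unique, unknown or untested is made for them only; others in the source may bear on it.

Measured compounds:
- compound 1 `COc1ccc(NC(=O)[C@@H]2CC=C(CCC=C(C)C)C[C@H]2c2ccccc2)cc1`: > 23000 nM
- compound 2 `CC(C)=CCCC1=CC[C@H](C(=O)Nc2ccc(O)cc2)[C@@H](c2ccccc2)C1`: > 23000 nM
- compound 3 `CC(C)=CCCC1=CC[C@H](C(N)=O)[C@@H](c2ccccc2)C1`: > 23000 nM

In an assay on isolated protein for inhibition of Apoptosis regulator Bcl-2 (Homo sapiens), read by fluorescence polarization, with stated times of 5 min and 10 min (on this read-out higher numbers stand for weaker inhibition and lower numbers for stronger inhibition), compound 1 gives only a limit, > 23000 nM, and not a number. Compound 2 likewise reaches only a limit in this assay. Compound 3 stands at a limit in this assay as well. Compound 1 therefore cannot be placed above or below the other two; all three sit at the limit of > 23000 nM in this assay, at which 3 of the 3 values shown sit, and nothing in these values separates them.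

Among the measured compounds shown here, the one single-point step among the measured compounds, a step that the two limits leave unreadable from compound 2 to compound 3, is unreadable for the same reason, so its size is unknown.

The compound to be measured next is compound 4 `CC(C)=CCCC1=CC[C@@H](C(=O)NCCC(=O)O)[C@H](c2ccccc2)C1`. It differs from compound 1 by 2-carboxyethyl in place of 4-methoxyphenyl on an amide-type nitrogen. For the measured compounds named here, no measured step bears on this change: the only step on the amide-type nitrogen, the one from compound 2 to compound 3, gives no size. With every measured value at the limit, the expectation for compound 4 rests on that alone, and a step beyond the scatter in either direction cannot be foreseen. Compound 4 is therefore expected to give 30000 nM, with a range from 8000 nM to 120000 nM. The step from compound 1 to compound 4 that this estimate means is a step that the limit leaves unreadable from compound 1 to compound 4, an expected step only.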

Compound 4, inhibition constant: > 23000 nM
Compound 4: no number, only a limit; the forecaster's own chance of this, stated with the estimate: 80%; the middle value is on the limit's open side.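

In this assay compound 4 gives > 23000 nM, which is a limit and not a number. No step can be read from compound 1 to compound 4, as the values shown stand together: the limit of > 23000 nM in this assay, at which 4 of the 4 values shown sit. The compounds shown leave open how strongly any of them inhibits and whether any change on the amide-type nitrogen alters that.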